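Acetyl versus methylsulfonyl on the pyrazole, and its attachment point

The source may report more compounds than this note shows. Statements on the series, on what has been measured and on what is new or still open speak of the compounds shown alone.

The measured compounds are:
compound 1, `CNC(=O)N1CCCc2ccc(NC(=O)c3cccc(-c4ccn(C(C)=O)n4)c3)cc21`, 87.6%
compound 2, `CNC(=O)N1CCCc2ccc(NC(=O)c3cccc(-c4cnn(S(C)(=O)=O)c4)c3)cc21`, 18%
compound 3, `CNC(=O)N1CCCc2ccc(NC(=O)c3cccc(-c4ccn(S(C)(=O)=O)n4)c3)cc21`, 37%

Compound 3 stands second highest of the three in a functional assay on MV4-11 cells (Homo sapiens) for antiproliferative activity, with a stated time of 6 days, tested at 6.25 uM; a lower number here means a weaker effect, a higher number a stronger effect of the compound at the concentration tested: compound 2 is nearest, a number 19 percentage points higher from compound 2 to compound 3 (beyond the scatter), while compound 1 is furthest, a number 50.6 percentage points lower from compound 1 to compound 3 (beyond the scatter).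

Compound 4, `CNC(=O)N1CCCc2ccc(NC(=O)c3cccc(-c4cnn(C(C)=O)c4)c3)cc21`, has not been measured. It differs from compound 3 in one place, (1-acetyl-1H-pyrazol-4-yl in place of 1-(methylsulfonyl)-1H-pyrazol-3-yl on an aromatic carbon).

For the measured compounds named here, two measured steps bear on this change. The step of a number 50.6 percentage points lower from compound 1 to compound 3 (beyond the scatter) shows what exchanging methylsulfonyl for acetyl on the aromatic nitrogen does, and the step of a number 19 percentage points higher from compound 2 to compound 3 (beyond the scatter) shows what moving from the 4-yl to the 3-yl attachment does. Compound 4 reverses both relative to compound 3: it regains the acetyl group but takes the 4-yl attachment. Taken together, a large upward step is expected, a number 29 percentage points higher from compound 3 to compound 4 (beyond the scatter), since the acetyl-for-methylsulfonyl effect was the larger of the two.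

Compound 4 is therefore estimated at 66% in this assay, with a range from 42% to 88%.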

Compound 4, a percentage reported as inhibition, at one concentration (the size of the read-out at that concentration, not a potency): 82%
For compound 4 the middle estimate is 16 percentage points below the measured one; measured number inside the range.
By their numbers in this assay, from the lowest: compound 2; then compound 3; then compounds 4 and 1 (each within the scatter of the next).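

In this assay, moving the attachment point of the acetylated pyrazole makes no clear difference (a number 5.6 percentage points lower from compound 1 to compound 4 (within the scatter)), so the 3-yl and 4-yl forms cannot be told apart while the acetyl group is present. That differs from the methylsulfonyl pair, where the attachment point gave a modest step, and the full replacement of 1-(methylsulfonyl)-1H-pyrazol-3-yl by 1-acetyl-1H-pyrazol-4-yl gives a large one (a number 45 percentage points higher from compound 3 to compound 4 (beyond the scatter)). The 4-yl attachment also shows a large step for acetyl in place of methylsulfonyl (a number 64 percentage points higher from compound 2 to compound 4 (beyond the scatter)), and the exchange has a similar size at both attachment points: the same change on two cores in this assay, a number 50.6 percentage points lower (beyond the scatter) from compound 1 to compound 3 and a number 64 percentage points lower (beyond the scatter) from compound 4 to compound 2, 13.4 percentage points apart, within the scatter of two such steps.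

As far as these compounds go, what a propanoyl group or a dimethylcarbamoyl group on the same pyrazole nitrogen would give remains open. From the compounds shown here alone, these read-outs come from one concentration, so the potencies of compound 1 and compound 4 also remain open.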